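Chloro for Nitrile on the Urea Aryl Ring

The source may report more compounds than this note shows. Statements on the series, on what has been measured and on what is new or still open speak of the compounds shown alone.

Compound 1 `CC1(C)CC(NC(=O)Nc2cccc(C#N)c2)c2cc(NS(C)(=O)=O)ccc2O1` — 9300 nM
Compound 2 `CC1(C)CC(NC(=O)Nc2ccc(C#N)cc2)c2cc(NS(C)(=O)=O)ccc2O1` — 19800 nM

Within the data shown here, in a functional assay on thoracic aorta (Rattus norvegicus) for inhibition (on this read-out higher numbers stand for an effect only at larger amounts of compound and lower numbers for an effect already at smaller amounts), compound 2 stands at the highest of the two numbers measured so far, with compound 1 the only neighbour; the step of a 2.1-fold higher number from compound 1 to compound 2 (0.33 log units; beyond the scatter) is modest but beyond the scatter. The unmeasured compound 3 `CC1(C)CC(NC(=O)Nc2cccc(Cl)c2)c2cc(NS(C)(=O)=O)ccc2O1` differs from compound 2 in one place: 3-chlorophenyl in place of 4-cyanophenyl on an amide-type nitrogen. Among the measured compounds shown here, only one measured step bears on this change, and only in part: a 2.1-fold higher number from compound 1 to compound 2 (0.33 log units; beyond the scatter) shows that going from 3-cyanophenyl to 4-cyanophenyl raised the number. For the measured compounds named here, compound 3 returns to a 3-substituted ring but with chlorine in place of the nitrile, and no measured pair covers that exchange. The expectation is therefore a return toward the value of compound 1, a step of a 2.5-fold lower number from compound 2 to compound 3 (0.39 log units; beyond the scatter) downward, with wide uncertainty. Compound 3 is estimated at 8000 nM, within a range of 3000 nM to 25000 nM.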

Compound 3, half-maximal effective concentration: 15200 nM
Estimate against measurement, compound 3: 1.9-fold (0.28 log units) below; the measured number falls inside the stated range.
By their numbers in this assay, from the lowest: compounds 1, 3 and 2 (each within the scatter of the next, the first and the last beyond it).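

Among these compounds, compound 3 gives the first direct reading of chloro in place of cyano on an aromatic carbon: in this assay the exchange gives a 1.6-fold higher number from compound 1 to compound 3 (0.21 log units; within the scatter) and so does not separate the two groups at this place. The exchange of 4-cyanophenyl for 3-chlorophenyl on the amide-type nitrogen gives a 1.3-fold lower number from compound 2 to compound 3 (0.11 log units; within the scatter) and is likewise unresolved. Compound 3 therefore cannot be told apart from either neighbour, and the step between the two nitrile compounds remains the only one beyond the scatter.

Going by these compounds, whether a methoxy group, an amine or a carboxylic acid in place of chloro on that aromatic carbon would give a number beyond the scatter of compound 1 stays open. Nothing available here offers an explanation for these numbers.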